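A few compounds are considered here, and "the series" means these few. Any claim that something is new, unique, unknown or untested is made for them only; others in the source may bear on it.

Working notes on the series. The set shares one core carrying a 4-methylphenyl group and a propanamide chain to a piperazine, with the piperazine substituent varied. Compound 1 `Cc1ccc(-c2cc(CCC(=O)N3CCN(CC4CCCO4)CC3)nn2-c2ccc(Cl)nn2)cc1` bears an oxolanylmethyl group on the piperazine; in an assay on isolated protein for inhibition of Polyunsaturated fatty acid 5-lipoxygenase (Homo sapiens), read by HPLC, with a stated time of 15 min, in the presence of a further agent that is not named here (on this read-out higher numbers stand for weaker inhibition and lower numbers for stronger inhibition), compound 1 gives "not determined" (no result reported). Compound 2 `CCS(=O)(=O)N1CCN(C(=O)CCc2cc(-c3ccc(C)cc3)n(-c3ccc(Cl)nn3)n2)CC1` carries an ethylsulfonyl group; in this assay compound 2 gives "not determined" (no result reported). Compound 3 `Cc1ccc(-c2cc(CCC(=O)N3CCN(Cc4ccc(C(C)(C)C)cc4)CC3)nn2-c2ccc(Cl)nn2)cc1` carries a 4-tert-butylbenzyl group, and in this assay compound 3 gives 2800 nM. Within the data shown here, compound 3 thus stands as the only entry with a number; the two other entries carry no figure, so no step between measured compounds can be set out.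

Compound 4 `Cc1ccc(-c2cc(CCC(=O)N3CCN(Cc4ccc(C(C)(C)C)cc4)CC3)nn2-c2ccc(Cl)cc2)cc1` keeps the 4-tert-butylbenzyl piperazine of compound 3 and differs only on the aromatic nitrogen of the core: 4-chlorophenyl in place of 6-chloropyridazin-3-yl on an aromatic nitrogen. Among the measured compounds shown here, no measured pair in this set separates this change, so no size of step is read from the data. With nothing in hand to move it either way, the step from compound 3 to compound 4 is expected to be small, a 1.1-fold lower number from compound 3 to compound 4 (0.05 log units; within the scatter), and to stay within the scatter in this assay. Compound 4 is therefore estimated at 2500 nM in this assay, with a range from 800 nM to 8000 nM.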

Compound 4, half-maximal inhibitory concentration: 2900 nM
Estimate against measurement, compound 4: 1.2-fold (0.06 log units) below; measured number inside the range.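

In this assay, among these compounds, 4-chlorophenyl in place of 6-chloropyridazin-3-yl on an aromatic nitrogen gives a 1.0-fold higher number from compound 3 to compound 4 (0.02 log units; within the scatter), the first step that can be read, and it lies within the scatter. With the 4-tert-butylbenzyl piperazine held constant, the two ring nitrogens and the hydrogen-bond acceptors counted on 6-chloropyridazin-3-yl are therefore not required for inhibition at this level, and a carbon-only six-membered aromatic ring serves equally well at this position. Nothing measured here bears on why this exchange leaves the read-out within the scatter.

Steps involving compound 1 and compound 2 cannot be read, so it remains open whether the same exchange would be equally silent with the oxolanylmethyl or ethylsulfonyl group on the piperazine. Also open, on these data alone, is whether this position tolerates groups of a different kind, such as a 4-aminophenyl or 4-carboxyphenyl group, or whether a chlorine on the aromatic ring is needed at all, as an unsubstituted phenyl group would show.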